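Dropping the methoxy group from a compound at the limit

The compounds below may be only part of what the source reports. "The series", "measured", "known", "first", "only" and "open" are said of these compounds alone.

Compound 1 `COc1c(Br)cccc1C(=O)Nc1ccc(Sc2nc3ccccc3s2)cc1` was tested in an assay for inhibition of HSP60/HSP10 (Homo sapiens), with a stated time of 60 min; a higher number here means a weaker inhibitor, a lower number a stronger inhibitor. In this assay compound 1 gives only a limit, > 100000 nM. Its close relative compound 2 `COc1c(Br)cc(Br)cc1C(=O)Nc1ccc(Sc2nc3ccccc3s2)cc1` carries a further bromo in place of hydrogen on an aromatic carbon and likewise reaches only a limit, giving > 100000 nM in this assay. The step that the two limits leave unreadable from compound 1 to compound 2 therefore cannot be read.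

Compound 3 `O=C(Nc1ccc(Sc2nc3ccccc3s2)cc1)c1cccc(Br)c1` differs from compound 1 by hydrogen in place of methoxy on an aromatic carbon. No measured step bears directly on this change; the only step shown adds a bromo group, and its size is not readable. With compound 1 and compound 2 both at the limit, nothing in the data points to a gain of potency from removing the methoxy group. Compound 3 is therefore expected to stay at or beyond the limit as well, an estimated step that the limit leaves unreadable from compound 1 to compound 3. The estimate for compound 3 in this assay is 200000 nM, with a range from 50000 nM to 1000000 nM.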

Compound 3, half-maximal inhibitory concentration: > 100000 nM
Compound 3 gave a limit, no number; the forecaster's own chance of this, stated with the estimate: 85%; the middle value does not contradict the limit.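

No step can be read from compound 1 to compound 3, since both compounds give only a limit: the limit of > 100000 nM in this assay, at which 3 of the 3 values shown sit.

The compounds shown leave open whether any change to the shared core would give a measurable value in this assay.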